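The source may hold more compounds than are shown below. What is called first, only, known or untested is meant among the compounds shown, and "the series" means these compounds.

The measured compounds, each with its result in a functional assay on A549 cells (Homo sapiens) for antiproliferative activity, read by MTT assay, with a stated time of 48 h; on this read-out higher numbers stand for weaker inhibition and lower numbers for stronger inhibition:

- compound 1, `COc1ccc(C(=O)c2ccc(OC)c3c2C=CC(C)(C)O3)c(NC(=O)CN)c1`, gives 420 nM
- compound 2, `CNCC(=O)Nc1cc(OC)ccc1C(=O)c1ccc(OC)c2c1C=CC(C)(C)O2`, gives 1370 nM
- compound 3, `C=C(c1ccc(OC)cc1NC(=O)CN)c1ccc(OC)c2c1OC(C)(C)C=C2`, gives 50 nM

Compound 1 and compound 2 share one core and differ in a single place: methyl in place of hydrogen on an amine nitrogen. That single change moved the read-out in this assay by a 3.3-fold higher number from compound 1 to compound 2 (0.51 log units; beyond the scatter), so adding the methyl made the inhibition of cell growth weaker in that pair.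

Compound 3 sits on a different core, and the difference between the two cores is not broken down here. Its number is the lowest of the three, and the gaps to both compound 1 and compound 2 are larger than the usual scatter, so compound 3 is the strongest inhibitor among the measured ones.

Compound 4, `C=C(c1ccc(OC)cc1NC(=O)CNC)c1ccc(OC)c2c1OC(C)(C)C=C2`, has not yet been measured in this assay. It is related to compound 3 exactly as compound 2 is related to compound 1: methyl in place of hydrogen on an amine nitrogen. The surroundings of the changed atom are the same in both pairs, so this is the same change carried onto the core of compound 3.

Among the compounds with values here, with only one earlier example, the expected size of the step from compound 3 to compound 4 is a 3.0-fold higher number from compound 3 to compound 4 (0.48 log units; beyond the scatter), taken from the result a 3.3-fold higher number from compound 1 to compound 2 (0.51 log units; beyond the scatter) seen on the other core. On that basis compound 4 is estimated to give about 150 nM, most likely somewhere between 60 nM and 400 nM.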

Compound 4, half-maximal inhibitory concentration: 150 nM
Compound 4: middle estimate and measured number agree at the digits printed; measured number inside the range.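

Placing a methyl on the amine nitrogen of compound 3 weakened the inhibition of cell growth in this assay, giving a 3.0-fold higher number from compound 3 to compound 4 (0.48 log units; beyond the scatter), the same direction as on the other core. Set side by side, the two steps match in size as closely as repeated measurements could show: the same change on two cores in this assay, a 3.3-fold higher number (0.51 log units; beyond the scatter) from compound 1 to compound 2 and a 3.0-fold higher number (0.48 log units; beyond the scatter) from compound 3 to compound 4, 1.1-fold (0.04 log units) apart, within the scatter of two such steps This shows that, in these two pairs, swapping hydrogen for methyl at this nitrogen carried a similar cost from one core to the other, although two pairs cannot show that the same would hold on a third core, and they do not explain why the methyl weakens inhibition.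

The compounds shown leave open what would happen with a larger group on this nitrogen, such as an ethyl group, or with a second methyl, which would give a dimethylamino group. They also leave open whether a longer chain carrying the amine, or a hydroxyl group in place of the amine, would follow the same pattern on both cores.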